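The source may report more compounds than this note shows. Statements on the series, on what has been measured and on what is new or still open speak of the compounds shown alone.

Measured so far:
Compound 1, `Cc1ccc(C(/N=C2\CCCCCN2)C2CC2)c(C)c1`: in a functional assay on the whole organism (plasma, strain Sprague-Dawley) with Rattus norvegicus as the target, with a stated time of 2 h, at a dose of 12.5 mg/kg by the oral route (on this read-out higher numbers stand for a stronger effect at the one dose given and lower numbers for a weaker effect), compound 1 gives 14%.
Compound 2, `c1csc(C(/N=C2\CCCCCCN2)C2CC2)c1`: in this assay compound 2 gives 17%.

Both numbers are small, and the gap between them lies within the usual scatter of repeated measurements, so compound 2 cannot be set apart from compound 1 on these two values alone; the pair simply marks a low level of effect for this core.

The next compound, compound 3, `c1ccc(C(/N=C2\CCCCCCN2)c2cccs2)cc1`, has not yet been tested. It differs from compound 2 in one place: phenyl in place of cyclopropyl on a saturated chain carbon bound to an aromatic carbon and a double-bonded nitrogen. The seven-membered ring with its double-bonded nitrogen and the thiophene part of compound 2 are kept.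

Among the compounds with values here, no measured pair shows what such an exchange does here, so there is no step to draw on. Within the data shown here, with only two weak values to go by, the change is expected to shift the read-out in this assay little, if at all, beyond the scatter, in either direction. The expected step is a number 3 percentage points higher from compound 2 to compound 3 (within the scatter). Compound 3 is therefore estimated to give 20%, with a range from 5% to 40%.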

Compound 3, a percentage reported as inhibition, in the whole organism at one dose (the size of the read-out at that dose, not a potency): 29%
Compound 3: middle estimate off by 9 percentage points, on the low side; the measured number falls inside the stated range.
By their numbers in this assay, from the lowest: compounds 1 and 2 (each within the scatter of the next); then compound 3.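

Within the data shown here, on the saturated chain carbon bound to an aromatic carbon and a double-bonded nitrogen, exchanging cyclopropyl for phenyl gives, in this assay, a step that can be read: a number 12 percentage points higher from compound 2 to compound 3 (beyond the scatter), and it is the first difference in this small set to stand clear of the usual scatter. This shows that the position is not indifferent to the group it carries, and that a six-membered aromatic ring of carbon only is accepted there and goes with a larger effect at the one dose given than the three-membered non-aromatic ring, although the step is modest and the read-out is not a potency. No measurement at hand bears on why the number rises.

Ring size and aromatic character change together in this single exchange, so a cyclohexyl group at the same carbon would be needed to separate the two. From the compounds shown here alone, whether a phenyl ring carrying a carboxylic acid or an amine would raise the effect further, or lower it, remains open.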